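Replacing the 4-fluorophenyl group of compound 2

The source may report more compounds than this note shows. Statements on the series, on what has been measured and on what is new or still open speak of the compounds shown alone.

Compound 1 `Cn1ccc2c(Oc3ccc(NC(=O)c4cc5cccnc5n(-c5ccccc5)c4=O)cc3)ncnc21` gives 59800 nM
Compound 2 `Cn1ccc2c(Oc3ccc(NC(=O)c4cc5cccnc5n(-c5ccc(F)cc5)c4=O)cc3F)ncnc21` gives 4250 nM

Both numbers come from a functional assay on HeLa cells (Homo sapiens) for cytotoxicity, read by MTT assay, with a stated time of 72 h (a higher number here means a weaker inhibitor, a lower number a stronger inhibitor), and the gap between them lies beyond the usual scatter. Compound 2 at 4250 nM is the stronger of the two, while compound 1 at 59800 nM is the weaker. These two compounds differ in more than one place, so their gap cannot be pinned on any single change.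

Compound 3 `Cn1ccc2c(Oc3ccc(NC(=O)c4cc5cccnc5n(-c5ccc(C(F)(F)F)c(Cl)c5)c4=O)cc3F)ncnc21` keeps the rest of compound 2 and alters one group. The change is 3-chloro-4-(trifluoromethyl)phenyl in place of 4-fluorophenyl on an aromatic nitrogen with 3-chloro-4-(trifluoromethyl)phenyl in place of 4-fluorophenyl on an aromatic nitrogen. Among the measured compounds shown here, no measured pair shows this change alone, so its effect in this assay has no direct guide and compound 2 at 4250 nM is the only close reference. A small shift towards a lower number is expected, probably not beyond the scatter. The estimated change is a 1.4-fold lower number from compound 2 to compound 3 (0.15 log units; within the scatter) and this remains only an expectation. For compound 3 the estimated value is 3000 nM with an expected range from 800 nM to 12000 nM until it is measured.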

Compound 3, half-maximal inhibitory concentration: 156000 nM
Compound 3: middle estimate off by 52-fold (1.72 log units), on the low side; the whole stated range lies below it.
By their numbers in this assay, from the lowest: compound 2; then compound 1; then compound 3.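

In this assay, the group on the aromatic nitrogen proves far from neutral: putting 3-chloro-4-(trifluoromethyl)phenyl in place of 4-fluorophenyl gives a 37-fold higher number from compound 2 to compound 3 (1.56 log units; beyond the scatter) and so a much weaker compound, the first effect here that can be traced to a single place in the structure. Both groups keep the same six-membered aromatic carbon ring, and neither has a hydrogen-bond donor or acceptor or a net charge, so the change lies in what that ring carries: a chlorine and a trifluoromethyl group instead of a single fluorine. This one step cannot show whether the chlorine, the trifluoromethyl group or the two together account for the loss, and no measurement here bears on the reason.

The compounds shown leave open how a phenyl ring carrying only a chlorine or only a trifluoromethyl group would behave at this position. They also leave open whether a smaller substituent such as a methoxy group, or a ring bearing an amine or a carboxylic acid, would be tolerated there.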